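The source may hold more compounds than are shown below. What is called first, only, known or untested is meant among the compounds shown, and "the series" means these compounds.

Measured compounds:
- compound 1 `COC(CCn1cnc2c(NCc3ccc(C(=O)Nc4ccccc4N)cc3)nc(Cl)nc21)OC`: 11.9%
- compound 2 `CC(C)n1cnc2c(Nc3ccccc3)nc(NCOCc3ccc(/C=C/C(=O)Nc4ccccc4N)cc3)nc21`: 41.7%
- compound 3 `Nc1ccccc1NC(=O)/C=C/c1ccc(COCNc2nc(Nc3cccc(Cl)c3)c3ncn(C4CCCC4)c3n2)cc1`: 9.19%

Of the compounds shown here, three sharing a related core have been tested in a functional assay on HCT-116 cells (Homo sapiens) for antiproliferative activity, read by CCK-8 assay, with a stated time of 72 h, tested at 8 uM; on this read-out lower numbers stand for a weaker effect and higher numbers for a stronger effect at the one concentration tested. Compound 2 gives 41.7%, compound 1 gives 11.9%, and compound 3 gives 9.19%. Compound 1 stands second highest of the three numbers; its value and that of compound 3 lie within the scatter of each other, so no order between them can be claimed, while compound 2 lies beyond the scatter above compound 1.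

The next compound, compound 4 `Nc1ccccc1NC(=O)c1ccc(CNc2nc(Cl)nc3c2ncn3Cc2ccccc2)cc1`, has not yet been measured in this assay. It differs from compound 1 in one place: phenyl in place of 2,2-dimethoxyethyl on a saturated chain carbon bound to an aromatic nitrogen. Among the measured compounds shown here, no measured pair shows this same change, so nothing directly tells how large its effect is.

Without such a comparison, the step from compound 1 to compound 4 is expected to be small, most likely none beyond the scatter, which is what a number 3.1 percentage points higher from compound 1 to compound 4 (within the scatter) expresses. Compound 4 is therefore estimated at 15% in this assay, with a plausible range from 3% to 35%.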

Compound 4, a percentage reported as inhibition, at one concentration (the size of the read-out at that concentration, not a potency): 11.5%
Compound 4: middle estimate off by 3.5 percentage points, on the high side, within the range that was stated.
By their numbers in this assay, from the lowest: compounds 3, 4 and 1 (each within the scatter of the next); then compound 2.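

In this assay, putting phenyl in place of 2,2-dimethoxyethyl on a saturated chain carbon bound to an aromatic nitrogen gives a number 0.4 percentage points lower from compound 1 to compound 4 (within the scatter). Among the compounds shown here, this is the first direct comparison at this position: an open chain with 2 hydrogen-bond acceptors gives way to an aromatic ring with none, at the same count of 6 heavy atoms, and the read-out does not separate the two compounds. No other measurement shown bears on this result.

As far as these compounds go, whether any group at this position can shift the read-out beyond the scatter remains open, for example an amine or a carboxylic acid on the chain. A single step also leaves open whether the same change would read alike on compounds with other groups elsewhere on the shared core.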